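The source may report more compounds than this note shows. Statements on the series, on what has been measured and on what is new or still open speak of the compounds shown alone.

Measured compounds so far:
- compound 1, `COc1nc(-c2cccc(Cl)c2)ccc1[C@@H](c1ccccc1)[C@@](O)(CCN(C)C)c1cccc2ccccc12`; in a toxicity assay on HeLa cells (Homo sapiens) for cytotoxicity (a higher number here means that more compound is tolerated, a lower number that less compound is tolerated), compound 1 gives "nd" (no result reported), that is, no reported result.
- compound 2, `COc1nc(-c2cccc(F)c2)ccc1[C@@H](c1ccccc1)[C@@](O)(CCN(C)C)c1cccc2ccccc12`; in this assay compound 2 gives 62.8 ug/mL.
- compound 3, `COc1ncc(-c2ccccc2)cc1[C@@H](c1ccccc1)[C@@](O)(CCN(C)C)c1cccc(F)c1F`; in this assay compound 3 gives 28.1 ug/mL.

Compound 1 stands without a number in this assay. Compound 2 and compound 3 each differ from compound 1 in more than one place, so neither offers a single step from which the position of compound 1 could be inferred; the two values for compound 2 and compound 3 are simply what the series shows, and the two compounds also differ from each other in more than one place.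

Compound 4, `COc1nc(C(C)(C)C)ccc1[C@@H](c1ccccc1)[C@@](O)(CCN(C)C)c1cccc2ccccc12`, is to be measured in this assay. It differs from compound 1 in one place: tert-butyl in place of 3-chlorophenyl on an aromatic carbon. For the measured compounds named here, no step between measured compounds covers this kind of change, and compound 1 itself carries no number, so the size of the step cannot be read from the series. The working expectation is a step of no more than the usual scatter in this assay, with no firm direction, and the value anchored near the two numbers that do exist. On that basis compound 4 is expected to give about 50 ug/mL, with a range from 20 ug/mL to 120 ug/mL.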

Compound 4, half-maximal cytotoxic concentration: > 64 ug/mL
Compound 4: only a limit was reported (the forecaster's own chance of this, stated with the estimate: 15%); middle value at least 1.2-fold (0.10 log units) away from the limit.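

In this assay compound 4 gives > 64 ug/mL, which is a limit of the assay and not a number: the limit of > 64 ug/mL in this assay, at which 1 of the 4 values shown sits.

For the compounds shown here, at the position next to the ring nitrogen, tert-butyl in place of 3-fluorophenyl gives an at least 1.0-fold higher number from compound 2 to compound 4 (0.00 log units; that floor lies within the scatter), the first step at this place that can be read, though its floor does not separate the two compounds. The position therefore carries a group with no ring as well as an aromatic ring, and the series shows no fall in the number with that change; the step between compound 1 and compound 4 cannot be read, as compound 1 has no number.

On these data alone, how far compound 4 actually stands from compound 2 stays open, and so does any order between tert-butyl and 3-fluorophenyl. Also open, as far as these compounds go, is how an amine, a carboxylic acid or a longer alkyl chain at this position would read in this assay, and whether tert-butyl would give a similar result on the core of compound 3.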